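A few compounds are considered here, and "the series" means these few. Any claim that something is new, unique, unknown or untested is made for them only; others in the source may bear on it.

Of the compounds shown here, three sharing one core have been measured in a functional assay on MCF7 cells (Homo sapiens) for cytotoxicity, read by MTT assay, with a stated time of 48 h; a lower number here means a stronger inhibitor, a higher number a weaker inhibitor. Compound 3 `COc1cc(-c2nnc3n2NC(c2ccco2)C(C(=O)c2cccc(Br)c2)S3)cc(OC)c1OC` gives 91800 nM, the higher of the two numbers shown. Compound 1 `COc1cc(-c2nnc3n2NC(c2ccco2)C(C(=O)c2ccc(F)c(F)c2)S3)cc(OC)c1OC` gives 73200 nM in this assay, and a 1.3-fold higher number from compound 1 to compound 3 (0.10 log units; within the scatter). Compound 2 `COc1cc(-c2nnc3n2NC(c2ccco2)C(C(=O)c2ccco2)S3)cc(OC)c1OC` in this assay reaches only > 100000 nM, which is a limit of the assay and not a number. This is the limit of > 100000 nM in this assay, at which 1 of the 3 values shown sits. Accordingly an at least 1.3-fold higher number from compound 1 to compound 2 (0.13 log units; that floor lies within the scatter), and an at least 1.0-fold lower number from compound 2 to compound 3 (0.03 log units; that floor lies within the scatter), so neither comparison adds anything beyond the scatter.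

Compound 4 `COc1cc(-c2nnc3n2NC(c2ccco2)C(C(=O)c2ccc(C(F)(F)F)cc2)S3)cc(OC)c1OC` has not yet been measured in this assay. It differs from compound 3 in one place: 4-(trifluoromethyl)phenyl in place of 3-bromophenyl on a carbonyl carbon. All three measured steps vary the group on the carbonyl carbon, and none of them moved the number beyond the scatter, so no step beyond the scatter is expected for a 1.0-fold lower number from compound 3 to compound 4 (0.01 log units; within the scatter). Compound 4 is therefore expected to give about 90000 nM in this assay, estimated within a range from 40000 nM to 200000 nM, with a real chance that only a limit is reported.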

Compound 4, half-maximal inhibitory concentration: 33600 nM
For compound 4 the middle estimate is 2.7-fold (0.43 log units) above the measured one; the measured number lies below the stated range.
By their numbers in this assay, from the lowest: compound 4; then compounds 1 and 3 (each within the scatter of the next). At a limit, above all of these: compound 2.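

Unlike the earlier steps, changing the group on the carbonyl carbon now moves the number beyond the scatter, with 4-(trifluoromethyl)phenyl replacing either 3-bromophenyl (a 2.7-fold lower number from compound 3 to compound 4 (0.44 log units; beyond the scatter)) or 3,4-difluorophenyl (a 2.2-fold lower number from compound 1 to compound 4 (0.34 log units; beyond the scatter)). In this assay compound 4 therefore has the lowest number of the four. Against furan-2-yl only a floor can be read (an at least 2.9-fold lower number from compound 2 to compound 4 (0.47 log units; beyond the scatter)), and compound 2 stands at a limit, not a number: (the limit of > 100000 nM in this assay, at which 1 of the 4 values shown sits).

The compounds shown leave open whether this shift follows the trifluoromethyl group itself or where it sits, which 3-(trifluoromethyl)phenyl and 4-bromophenyl would separate. They also leave open what an amine or a carboxylic acid on the phenyl ring, or a saturated chain on the carbonyl carbon, would do to the number.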